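Series notes: an ortho chloro on the benzylsulfanyl group

The source may hold more compounds than are shown below. What is called first, only, known or untested is meant among the compounds shown, and "the series" means these compounds.

Compound 1 `COc1ccc(C2N=C(SCc3ccccc3Cl)NC(C)=C2C(=O)Nc2ccc(F)cc2)cc1OC` — in a functional assay on the whole organism (artery, strain albino) with Rattus norvegicus as the target, with a stated time of 30 min, at a dose of 10 mg/kg by the oral route (a higher number here means more inhibition at the dose given (going by the name of the read-out), a lower number less inhibition), compound 1 gives 6.2%.
Compound 2 `CC1=C(C(=O)Nc2ccc(Br)cc2)C(c2ccc(Cl)cc2Cl)N=C(SCc2ccc(F)cc2)N1` — in this assay compound 2 gives 7.7%.
Compound 3 `CC1=C(C(=O)Nc2ccc([N+](=O)[O-])cc2)C(c2ccc(Br)cc2)N=C(SCc2ccccc2)N1` — in this assay compound 3 gives 3.6%.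

Compound 3 sits at the low end of the three numbers, yet its gaps to compound 1 and to compound 2 both lie within the usual scatter, so the three are not told apart. Within the data shown here, no pair of measured compounds differs in one place, so no single step has been measured.

Compound 4 `CC1=C(C(=O)Nc2ccc([N+](=O)[O-])cc2)C(c2ccc(Br)cc2)N=C(SCc2ccccc2Cl)N1` is the next compound. Its change from compound 3 is chloro in place of hydrogen on an aromatic carbon. Compound 1 carries the same 2-chlorobenzyl group and gives a number in the same band, so no step beyond the scatter is expected in this assay. The step from compound 3 to compound 4 is estimated as a number 1.4 percentage points higher from compound 3 to compound 4 (within the scatter). Compound 4 is expected to give 5%, within 0% to 14%.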

Compound 4, a percentage reported as inhibition, in the whole organism at one dose (the size of the read-out at that dose, not a potency): 3.6%
The estimate for compound 4 lay 1.4 percentage points above the measured number; low and high end bracket the measured number.
By their numbers in this assay, from the lowest: compounds 3, 4, 1 and 2 (each within the scatter of the next).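

Among these compounds, this is the first single step read: chloro in place of hydrogen on an aromatic carbon gives no change at the digits printed from compound 3 to compound 4 (within the scatter) in this assay. With the rest of the structure held constant, benzylsulfanyl and (2-chlorobenzyl)sulfanyl are therefore not told apart at this dose. No measurement on hand explains this result.

On these data alone, whether an amine or a carboxylic acid at this place would give a step beyond the scatter remains open. Also open, as far as these compounds go, is whether the chloro step reads the same with other groups on the shared core.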